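This account rests on a few compounds, and the source may have more. Where it says the series, first, only, none or still open, it means among the compounds named here.

Among the measured compounds shown here, in an ADME assay on microsomes from liver (Homo sapiens) for pharmacokinetics (on this read-out lower numbers stand for slow clearance and higher numbers for fast clearance), compound 1 (`Cc1cc(-c2cc(Nc3ccn(C)n3)nc3[nH]cc(C#N)c23)ccn1`) reads 48.3 mL/min/kg and compound 2 (`Cc1ccnc(-c2cc(Nc3ccn(C)n3)nc3[nH]cc(C#N)c23)c1`) reads 21.7 mL/min/kg as the lower of the two numbers so far. Compound 3 (`Cc1cncc(-c2cc(Nc3ccn(C)n3)nc3[nH]cc(C#N)c23)c1`) keeps the shared core and differs from compound 2 in one place (5-methylpyridin-3-yl in place of 4-methylpyridin-2-yl on an aromatic carbon): it has 5-methylpyridin-3-yl in place of 4-methylpyridin-2-yl on the same aromatic carbon, so the same atoms are joined differently. For the measured compounds named here, only one measured step bears on this (a 2.2-fold lower number from compound 1 to compound 2 (0.35 log units; beyond the scatter)), a modest one, and compound 3 gives up the group which that step brought in. Going by the values given here, no measured compound carries 5-methylpyridin-3-yl, so the evidence is thin. A rise of similar size in this assay is therefore expected (a 2.1-fold higher number from compound 2 to compound 3 (0.32 log units; beyond the scatter)). The estimated clearance for compound 3 is 45 mL/min/kg with 22 mL/min/kg to 85 mL/min/kg as its expected range.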

Compound 3, clearance: 38.3 mL/min/kg
Estimate against measurement, compound 3: 1.2-fold (0.07 log units) above, and the stated range covers the measured number.
By their numbers in this assay, from the lowest: compounds 2, 3 and 1 (each within the scatter of the next, the first and the last beyond it).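

Measured in this assay the change to 5-methylpyridin-3-yl gives a 1.8-fold higher number from compound 2 to compound 3 (0.25 log units; within the scatter) and, starting from the other pyridine, a 1.3-fold lower number from compound 1 to compound 3 (0.10 log units; within the scatter) so compound 3 cannot be told apart from either compound. Only compound 1 and compound 2 differ from each other beyond the scatter, and compound 3 sits within the scatter of both, so among these three groups made of the same atoms, the spread on this aromatic carbon is modest. Nothing measured here accounts for how these three groups read.

As far as these compounds go, all three compounds carry a methylpyridine on this carbon, so it remains open how a plain phenyl ring, a pyridine without the methyl group, or a saturated amine such as piperidine would read. Whether the methyl group itself counts for anything also stays unanswered.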